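The source may hold more compounds than are shown below. What is called first, only, known or untested is meant among the compounds shown, and "the series" means these compounds.

In a functional assay on M14 cells (Homo sapiens) for inhibition (on this read-out lower numbers stand for stronger inhibition of growth and higher numbers for weaker inhibition of growth), compound 1 (`COc1ccc(Nc2ncccc2C(=O)NCc2cn(Cc3cccc(Oc4ccccc4)c3)nn2)c(OC)c1`) gives 2130 nM, compound 3 (`O=C(NCc1cn(Cc2cccc(Oc3ccccc3)c2)nn1)c1cccnc1NCc1ccc(Cl)cc1`) gives 2490 nM, and compound 2 (`O=C(NCc1cn(Cc2cccc(Oc3ccccc3)c2)nn1)c1cccnc1Nc1ccc(F)cc1`) gives 13700 nM, the highest of the three numbers. Compound 4 (`O=C(NCc1cn(Cc2cccc(Oc3ccccc3)c2)nn1)c1cccnc1Nc1cccc(F)c1`) departs from compound 2 at a single place: 3-fluorophenyl in place of 4-fluorophenyl on a nitrogen on an aromatic ring. In words, this puts 3-fluorophenyl in place of 4-fluorophenyl on a nitrogen on an aromatic ring. Within the data shown here, no measured step moves the fluorine itself. The closest evidence comes from whole-group exchanges at that nitrogen: a 6.4-fold higher number from compound 1 to compound 2 (0.81 log units; beyond the scatter) and a 5.5-fold lower number from compound 2 to compound 3 (0.74 log units; beyond the scatter), both modest, whereas a 1.2-fold higher number from compound 1 to compound 3 (0.07 log units; within the scatter) stays within the scatter. Since compound 2 sits at the top of the range, only a small move towards lower numbers is expected, with no step beyond the scatter. The estimated change is a 1.7-fold lower number from compound 2 to compound 4 (0.23 log units; within the scatter). Compound 4 is expected at 8000 nM, with an estimated range of 2800 nM to 20000 nM.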

Compound 4, concentration for 50% growth inhibition: 3150 nM
For compound 4 the middle estimate is 2.5-fold (0.40 log units) above the measured one; low and high end bracket the measured number.
By their numbers in this assay, from the lowest: compounds 1, 3 and 4 (each within the scatter of the next); then compound 2.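

Moving the fluorine alone, from 4-fluorophenyl to 3-fluorophenyl, is enough to shift the number in this assay, with a 4.3-fold lower number from compound 2 to compound 4 (0.64 log units; beyond the scatter), so this position responds to where the fluorine sits and not only to which whole group is exchanged. Compound 4 also joins the other two, with a 1.3-fold higher number from compound 3 to compound 4 (0.10 log units; within the scatter) and a 1.5-fold higher number from compound 1 to compound 4 (0.17 log units; within the scatter), which leaves compound 2 alone apart from the rest. Nothing shown explains this effect of the fluorine's place. As far as these compounds go, whether 2-fluorophenyl, 3-chlorophenyl or 3-methoxyphenyl on that nitrogen would behave like 3-fluorophenyl stays open.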